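Swapping fluoro for tert-butyl on the aromatic ring

The source may hold more compounds than are shown below. What is called first, only, known or untested is meant among the compounds shown, and "the series" means these compounds.

In a functional assay on MCF7 cells (Homo sapiens) for antiproliferative activity, read by MTT assay, with a stated time of 72 h (on this read-out higher numbers stand for weaker inhibition and lower numbers for stronger inhibition), compound 2 `O=C(COc1ccc(C(=O)/C=C/c2ccc(F)cc2)cc1)N[C@H]1CCOC1=O` gives only > 64000 nM, which is a limit of the measurement rather than a number (the limit of > 64000 nM in this assay, at which 1 of the 2 values shown sits). Compound 1 `O=C(COc1ccc(C(=O)/C=C/c2ccc(Cl)cc2Cl)cc1)N[C@H]1CCOC1=O` gives 34400 nM in this assay. Within the data shown here, the single measured step, an at least 1.8-fold higher number from compound 1 to compound 2 (0.26 log units; that floor lies within the scatter), is the only guide, and it stays within scatter. Compound 3 `CC(C)(C)c1ccc(/C=C/C(=O)c2ccc(OCC(=O)N[C@H]3CCOC3=O)cc2)cc1` carries tert-butyl in place of fluoro on an aromatic carbon. Among the measured compounds shown here, no measured step shows which way tert-butyl moves the number, so the expected step is an at least 1.4-fold lower number from compound 2 to compound 3 (0.15 log units; that floor lies within the scatter), with no direction beyond scatter. Compound 3 is therefore estimated at 45000 nM, within a range of 15000 nM to 150000 nM.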

Compound 3, half-maximal inhibitory concentration: 16400 nM
Beside the measured number, compound 3's estimate is 2.7-fold (0.44 log units) above it; measured number inside the range.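

Among these compounds, with tert-butyl, this position gives the first step beyond the scatter from compound 2: an at least 3.9-fold lower number from compound 2 to compound 3 (0.59 log units; beyond the scatter). That size is only a floor, because the value of compound 2 is a limit and not a number: the limit of > 64000 nM in this assay, at which 1 of the 3 values shown sits.

Changing 2,4-dichlorophenyl to 4-(tert-butyl)phenyl also goes beyond the scatter, giving a 2.1-fold lower number from compound 1 to compound 3 (0.32 log units; beyond the scatter).

From the compounds shown here alone, what a methyl group or an amine would do in place of tert-butyl remains open. The three compounds also cannot show whether the number keeps falling with larger carbon groups at this position.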